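Ester Chain Length in a Series of Inactive Glycosides

A few compounds are considered here, and "the series" means these few. Any claim that something is new, unique, unknown or untested is made for them only; others in the source may bear on it.

Compound 1, `C/C=C1/[C@H](O[C@@H]2O[C@H](CO)[C@@H](O)[C@H](O)[C@H]2O)OC=C(C(=O)OC)[C@H]1CC(=O)O`: > 15000 nM
Compound 2, `C/C=C1/[C@H](O[C@@H]2O[C@H](CO)[C@@H](O)[C@H](O)[C@H]2O)OC=C(C(=O)OC)[C@H]1CC(=O)OCCCC`: > 15000 nM
Compound 3, `C/C=C1/[C@H](O[C@@H]2O[C@H](CO)[C@@H](O)[C@H](O)[C@H]2O)OC=C(C(=O)OC)[C@H]1CC(=O)OCCc1ccc(OC)cc1`: > 20000 nM

The three compounds share one core and differ only in the group on an oxygen next to a carbonyl group. In a functional assay on SK-BR-3 cells (Homo sapiens) for antiproliferative activity, read by MTT assay, with a stated time of 72 h (on this read-out lower numbers stand for stronger inhibition and higher numbers for weaker inhibition), compound 1 gives > 15000 nM, which is a limit of the assay rather than a number. In this assay compound 2 gives > 15000 nM, again a limit. Compound 3 gives > 20000 nM in this assay, also a limit. Compound 3 therefore stands nowhere on a scale of numbers: like the other two, it shows no measurable inhibition within the tested range, sitting at the limit of > 20000 nM in this assay, at which 1 of the 3 values shown sits, while the others sit at the limit of > 15000 nM in this assay, at which 2 of the 3 values shown sit.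

Within the data shown here, compound 4, `C/C=C1/[C@H](O[C@@H]2O[C@H](CO)[C@@H](O)[C@H](O)[C@H]2O)OC=C(C(=O)OC)[C@H]1CC(=O)OCCC`, is the unmeasured member. methyl in place of 4-methoxyphenyl on a saturated chain carbon, two bonds along the chain from an oxygen next to a carbonyl group The steps that bear on this change are a step that the two limits leave unreadable from compound 1 to compound 2 and a step that the two limits leave unreadable from compound 2 to compound 3, and with both unreadable there is no sign of any step beyond the scatter in this assay. Compound 4 is expected to report only a limit as well, so the expected step that the limit leaves unreadable from compound 3 to compound 4 is nominal. Compound 4 is estimated at 25000 nM, within a range from 15000 nM to 60000 nM.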

Compound 4, half-maximal inhibitory concentration: > 15000 nM
Compound 4: a limit, no number; the forecaster's own chance of this, stated with the estimate: 90%; the middle value does not contradict the limit.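

In this assay compound 4 gives > 15000 nM, a limit of the assay and not a number. Among these compounds, compound 1, compound 2 and compound 3 also report only limits, and no step from any of them to compound 4 can be read. The compounds shown leave open whether any of the four inhibits measurably at higher concentrations, and how they would then rank.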